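The source may hold more compounds than are shown below. What is called first, only, known or untested is meant among the compounds shown, and "the series" means these compounds.

Compound 1 `CCN(CC)CCCOc1ccc(C(=O)/C=C/c2ccc(N(C)C)cc2)c(O)c1` is tested in an assay on isolated protein for inhibition of Amine oxidase [flavin-containing] A (Homo sapiens) (a higher number here means a weaker inhibitor, a lower number a stronger inhibitor), where compound 1 gives 47100 nM. Among the compounds with values here, the only other measured compound, compound 2 `CCN(CCCCCCOc1ccc(C(=O)/C=C/c2ccc(N(C)C)cc2)c(O)c1)Cc1ccccc1`, gives 31600 nM in this assay, and the two numbers lie within the usual scatter of each other, so neither compound stands apart. Compound 3 `CCN(CCCOc1ccc(C(=O)/C=C/c2ccc(N(C)C)cc2)c(O)c1)Cc1ccccc1N(C)C` differs from compound 1 by 2-(dimethylamino)phenyl in place of methyl on a saturated chain carbon bound to an amine nitrogen. Within the data shown here, no measured pair shows what this change does, so the step is expected to be a modest gain in potency, a 1.9-fold lower number from compound 1 to compound 3 (0.28 log units; within the scatter), hardly beyond the scatter. Compound 3 is therefore estimated at 25000 nM, with a range from 8000 nM to 70000 nM.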

Compound 3, half-maximal inhibitory concentration: 23600 nM
The estimate for compound 3 lay 1.1-fold (0.03 log units) above the measured number; measured number inside the range.
By their numbers in this assay, from the lowest: compounds 3, 2 and 1 (each within the scatter of the next).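

Putting 2-(dimethylamino)phenyl in place of methyl on a saturated chain carbon bound to an amine nitrogen gives a 2.0-fold lower number from compound 1 to compound 3 (0.30 log units; within the scatter) in this assay. This position therefore takes a far larger group, with an aromatic ring, and the number stays within the scatter of that of compound 1. Nothing available explains this result.

Going by these compounds, whether the dimethylamino group itself matters stays open. A 2-methoxybenzyl group or a cyclohexylmethyl group in place of the 2-(dimethylamino)benzyl group would test the roles of that substituent and of the aromatic ring.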